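Urea to amide: a carbonyl-side swap in compound 3

The source may report more compounds than this note shows. Statements on the series, on what has been measured and on what is new or still open speak of the compounds shown alone.

Measured so far:
Compound 1, `O=C(Nc1cccc(-n2cc(-c3ccncc3)c(-c3cc(O)cc(Cl)c3)n2)c1)Nc1ccc(Cl)c(C(F)(F)F)c1`, gives 58% in a functional assay on A498 cells (Homo sapiens) for inhibition, read by sulforhodamine B assay, with a stated time of 48 h, tested at 0.01 uM; on this read-out lower numbers stand for a stronger effect and higher numbers for a weaker effect at the one concentration tested.
Compound 2, `COc1cc(Cl)cc(-c2nn(-c3cccc(NC(=O)Nc4ccc(Cl)c(C(F)(F)F)c4)c3)cc2-c2ccncc2)c1`, gives 57% in this assay.

For the measured compounds named here, compound 2 holds the lowest of the two numbers, with compound 1 nearest, and the only measured step, a number 1 percentage points lower from compound 1 to compound 2 (within the scatter), lies within the scatter. Compound 3, `COc1cc(Cl)cc(-c2nn(-c3cccc(NC(=O)c4cccc(C(F)(F)F)c4)c3)cc2-c2ccncc2)c1`, differs from compound 2 at a different site: 3-(trifluoromethyl)phenyl in place of (4-chloro-3-(trifluoromethyl)phenyl)amino on a carbonyl carbon. Going by the values given here, no measured step touches this carbonyl side of the molecule, so the one step known, on the methyl of the oxygen, gives no guide to the size or direction here. The change is larger than that methyl step, so the uncertainty is wide. For compound 3 the number is expected to be somewhat higher, that is a weaker effect, near 72% with a range from 45% to 98%, a step of a number 15 percentage points higher from compound 2 to compound 3 (beyond the scatter).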

Compound 3, a percentage reported as activity, at one concentration (the size of the read-out at that concentration, not a potency): 58%
For compound 3 the middle estimate is 14 percentage points above the measured one; low and high end bracket the measured number.
By their numbers in this assay, from the lowest: compounds 2, 1 and 3 (each within the scatter of the next).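

For the compounds shown here, until now, the only measured step touched the methyl on an oxygen, so this is the first look at the carbonyl side of the molecule. Putting 3-(trifluoromethyl)phenyl in place of (4-chloro-3-(trifluoromethyl)phenyl)amino on the carbonyl carbon turns the urea into an amide, and in this assay it gives a number 1 percentage points higher from compound 2 to compound 3 (within the scatter). The group that leaves counts 1 hydrogen-bond donor and the group that enters counts 0, yet this single-concentration read-out does not separate the two compounds, although the nitrogen and the chlorine go in one swap, so neither can be judged alone.

Still open is what a different group on this carbonyl carbon, such as a methyl or a dimethylamino group, would give in this assay, and no measurement shown here explains why compound 2 and compound 3 read so alike.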